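Sulfanyl ester in the side chain of compound 2

A few compounds are considered here, and "the series" means these few. Any claim that something is new, unique, unknown or untested is made for them only; others in the source may bear on it.

In a functional assay on the whole organism (strain Hartley) for inhibition, with Cavia porcellus as the target, with stated times of 15 min and 2 min (a higher number here means that more compound is needed for the effect, a lower number that less compound is needed), compound 1 (`CCCCC1([C@@H](O)/C=C/C2CCC(=O)[C@@H]2CCCCCCC(=O)O)CCC1`) gives 0.0203 mg/kg and compound 2 (`CCCCC1([C@H](O)/C=C/C2CCC(=O)[C@@H]2CCCCCC(=O)O)CCC1`) gives 0.032 mg/kg and so stands within the scatter of compound 1. Compound 3 (`CCCCC1([C@H](O)/C=C/C2CCC(=O)[C@@H]2CCCCSCC(=O)OCC)CCC1`) carries ((ethoxycarbonyl)methyl)sulfanyl in place of carboxymethyl on a saturated chain carbon, four bonds along the chain from a saturated ring carbon. Going by the values given here, no measured pair shows this kind of change, so only a slight move towards more compound needed is expected. The estimated step (a 1.3-fold higher number from compound 2 to compound 3 (0.10 log units; within the scatter)) stays within the scatter. Compound 3 is estimated at 0.04 mg/kg with 0.012 mg/kg to 0.13 mg/kg as the expected range.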

Compound 3, dose for half-maximal effect: 0.3 mg/kg
Compound 3: the middle estimate sits 7.5-fold (0.88 log units) below what was measured, outside the stated range (above it).
By their numbers in this assay, from the lowest: compounds 1 and 2 (each within the scatter of the next); then compound 3.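

In this assay the chain end proves sensitive to this change: ((ethoxycarbonyl)methyl)sulfanyl in place of carboxymethyl gives a 9.4-fold higher number from compound 2 to compound 3 (0.97 log units; beyond the scatter) and so needs clearly more compound. Going by these compounds alone, this is the first step that can be tied to one place, on a saturated chain carbon, four bonds along the chain from a saturated ring carbon. No measured finding accounts for the step.

Going by these compounds, the sulfur and the ethyl ester enter together, so their separate contributions remain open. A sulfanyl chain ending in the free carboxylic acid would separate them.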